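Hexokinase-2 inhibitors: ester to acid on the furan-free sulfonamide arm

The compounds below may be only part of what the source reports. "The series", "measured", "known", "first", "only" and "open" are said of these compounds alone.

Compound 1 `O=C(N[C@H]1C(O)O[C@H](CO)[C@@H](O)[C@@H]1O)c1cc([N+](=O)[O-])cc([N+](=O)[O-])c1` and compound 2 `COC(=O)c1cc(S(=O)(=O)NC[C@H]2OC(O)[C@H](NC(=O)c3cccc(Br)c3)[C@@H](O)[C@@H]2O)oc1C` have been measured in an assay for inhibition of hexokinase-2 (Homo sapiens), read by ADP-Glo, with a stated time of 45 min, in the presence of a further agent that is not named here; on this read-out lower numbers stand for stronger inhibition and higher numbers for weaker inhibition. Compound 1 gives 2000 nM, while compound 2 gives 630 nM, the lower of the two numbers by a margin beyond the scatter. Compound 3 `Cc1oc(S(=O)(=O)NC[C@H]2OC(O)[C@H](NC(=O)c3cccc(Br)c3)[C@@H](O)[C@@H]2O)cc1C(=O)O` differs from compound 2 by hydrogen in place of methyl on an oxygen next to a carbonyl group, that is, methoxycarbonyl to carboxy. Going by the values given here, no measured pair shows this change, so no step size can be read from the series. The step from compound 2 to compound 3 is expected to be a 1.3-fold higher number from compound 2 to compound 3 (0.10 log units; within the scatter), within the scatter rather than a clear move. For compound 3 the estimate in this assay is 800 nM, within 250 nM to 2500 nM.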

Compound 3, half-maximal inhibitory concentration: 10 nM
For compound 3 the middle estimate is 80-fold (1.90 log units) above the measured one; measured number below the stated range.
By their numbers in this assay, from the lowest: compound 3; then compound 2; then compound 1.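

In this assay, going by these compounds alone, the change from methoxycarbonyl to carboxy gives a 63-fold lower number from compound 2 to compound 3 (1.80 log units; beyond the scatter) and is the first single-place comparison. At this place, the loss of one methyl group alone is enough to produce a large move in the number. Nothing at hand accounts for the size of this step.

On these data alone, it remains open whether the move is particular to the carboxy group or would also appear with a primary carboxamide or a hydroxymethyl group here. Also open, as far as these compounds go, is whether the same change would give a step of similar size on the dinitrobenzoyl amide of compound 1.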